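The source may hold more compounds than are shown below. What is called first, only, known or untested is meant among the compounds shown, and "the series" means these compounds.

Compound 1 `Nc1sccc1C(=O)c1ccc(Cl)cc1` is tested in an assay on CHO cells for positive allosteric modulation of adenosine receptor A1 (Homo sapiens), read by ERK phosphorylation, tested at 3 uM; a lower number here means a stronger effect, a higher number a weaker effect of the compound at the concentration tested. Compound 1 gives 50%, level at the digits printed with compound 2 `CN(C)c1ccc(-c2cc(C(=O)c3ccccc3)c(N)s2)cc1`, which gives 50%, and close to compound 3 `Nc1sc(-c2ccc(C(=O)O)cc2)cc1C(=O)c1ccccc1`, which gives 51%. The only single-point step among these three, a number 1 percentage points higher from compound 2 to compound 3 (within the scatter), changes a group on the phenyl ring and stays within the scatter. Compound 4 `Nc1sc(-c2ccccc2)cc1C(=O)c1ccc(Cl)cc1` differs from compound 1 by phenyl in place of hydrogen on an aromatic carbon. Going by the values given here, no measured step swaps hydrogen for phenyl at that place; compounds 2 and 3, which carry a substituted phenyl there, merely show values close to compound 1 in this assay. Compound 4 is therefore expected to show no change beyond the scatter, a step of no change at the digits printed from compound 1 to compound 4 (within the scatter), giving an estimate of 50%, ranging from 38% to 62%.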

Compound 4, a percentage reported as activity, at one concentration (the size of the read-out at that concentration, not a potency): 46%
Compound 4: middle estimate off by 4 percentage points, on the high side; the range from low to high includes it.
By their numbers in this assay, from the lowest: compounds 4, 1, 2 and 3 (each within the scatter of the next).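

Swapping hydrogen for phenyl on the aromatic carbon next to the ring sulfur now has a direct reading in this assay: the step is a number 4 percentage points lower from compound 1 to compound 4 (within the scatter). Going by these compounds alone, an unsubstituted phenyl at this place therefore leaves the read-out within the scatter of the hydrogen compound, which the earlier compounds could only hint at. No available evidence bears on why this is so.

Going by these compounds, whether a methyl group or a longer chain such as butyl at this carbon would also leave the read-out unmoved remains open. An amine attached directly there is likewise an open question.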